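Swapping nitro for amino on an oxime

The source may hold more compounds than are shown below. What is called first, only, known or untested is meant among the compounds shown, and "the series" means these compounds.

Compounds measured so far in a functional assay on KB cells (Homo sapiens) for antiproliferative activity, read by MTT assay, with a stated time of 72 h; a lower number here means a stronger inhibitor, a higher number a weaker inhibitor:

- compound 1 `COc1ccc(-c2ssc(=O)c2-c2cc(OC)c(OC)c(OC)c2)cc1O` gives 460 nM here
- compound 2 `COc1ccc(-c2c(-c3cc(OC)c(OC)c(OC)c3)ss/c2=N/O)cc1` gives > 100000 nM here, a limit of the assay and not a number
- compound 3 `COc1ccc(-c2c(-c3cc(OC)c(OC)c(OC)c3)ss/c2=N/O)cc1[N+](=O)[O-]` gives 5260 nM here

Of the two true numbers, compound 3 has the higher one, so it is the weaker inhibitor, and compound 1 lies lower by more than the scatter. The next molecule, compound 4 `COc1ccc(-c2c(-c3cc(OC)c(OC)c(OC)c3)ss/c2=N/O)cc1N`, differs from compound 3 by one swap of amino in place of nitro on an aromatic carbon, ortho to a methoxy group: amino in place of nitro on an aromatic carbon (the counted difference).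

Among the measured compounds shown here, only one measured step touches this carbon. It runs an at least 19-fold lower number from compound 2 to compound 3 (1.27 log units; beyond the scatter) and is large, so a change here can move the number strongly. For the measured compounds named here, that step put nitro in place of hydrogen, and no measured step replaces nitro with amino, so the direction remains a judgement. Compound 1, with a hydroxyl group on the same ring and a carbonyl instead of the oxime, gives 460 nM and shows that lower numbers are reachable in this series. A moderate move of a 3.5-fold lower number from compound 3 to compound 4 (0.54 log units; beyond the scatter) is therefore expected in this assay as a modest gain. Compound 4 is expected at 1500 nM as an estimate, with an estimated range from 150 nM to 15000 nM in this measurement.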

Compound 4, half-maximal inhibitory concentration: 2910 nM
Estimate against measurement, compound 4: 1.9-fold (0.29 log units) below; measured number inside the range.
By their numbers in this assay, from the lowest: compound 1; then compounds 4 and 3 (each within the scatter of the next). At a limit, above all of these: compound 2.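

In this assay, the swap of amino in place of nitro on this aromatic carbon gives a 1.8-fold lower number from compound 3 to compound 4 (0.26 log units; within the scatter), so these two groups cannot be told apart at this position. Amino in place of hydrogen gives an at least 34-fold lower number from compound 2 to compound 4 (1.53 log units; beyond the scatter), which shows that the large step seen with nitro is not confined to that one group. Compound 2 stands at a limit of the assay and not at a number: the limit of > 100000 nM in this assay, at which 1 of the 4 values shown sits.

The compounds shown leave open whether a carboxylic acid, a fluorine atom or an acetamide on this carbon would stay in the same range or move the number. Among the compounds shown here, the part played by the oxime also stays unread, as compound 1 differs from compound 4 in more than one place and no step between them can be read.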